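Swapping the aryl on the chain carbon for benzyl

The source may hold more compounds than are shown below. What is called first, only, known or untested is meant among the compounds shown, and "the series" means these compounds.

Compound 1 `CCCCCCCCCCCCn1nnc(C(C(=O)Nc2ncccc2C)c2ccccc2)n1`: 4%
Compound 2 `CCCCCCCCCCCCn1nnc(C(C(=O)Nc2c(OC)ncnc2OC)c2ccccc2)n1`: 39%
Compound 3 `CCCCCCCCCCCCn1nnc(C(C(=O)Nc2c(OC)cc(OC)cc2OC)c2ccc(N(C)C)cc2)n1`: 0%

All three measured compounds share one core and were tested in an assay on isolated protein for inhibition of sterol O-acyltransferase 1 (Mus musculus), tested at 0.1 uM; a higher number here means more inhibition at the concentration tested (going by the name of the read-out), a lower number less inhibition. Compound 3 sits at the bottom of the set with 0%, yet its gap to compound 1 lies within the scatter, so the two cannot be ranked; only compound 2 stands clearly apart, beyond the scatter above it. Within the data shown here, the one measured step, a number 35 percentage points higher from compound 1 to compound 2 (beyond the scatter), concerns a change on the amide-type nitrogen.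

Compound 4 `CCCCCCCCCCCCn1nnc(C(Cc2ccccc2)C(=O)Nc2c(OC)cc(OC)cc2OC)n1` arises from compound 3 by a change at a different place: benzyl in place of 4-(dimethylamino)phenyl on a saturated chain carbon bound to an aromatic carbon and a carbonyl carbon. Among the measured compounds shown here, no measured step touches this position, so the step 1>2 offers no direct guide, and the only anchor is the value of compound 3 itself. A small rise is plausible but not required, and nothing beyond the scatter is expected with confidence. In this assay compound 4 is therefore estimated at 10%, with a range from 0% to 35%, which means an expected step of a number 10 percentage points higher from compound 3 to compound 4 (within the scatter).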

Compound 4, a percentage reported as inhibition, at one concentration (the size of the read-out at that concentration, not a potency): 77%
For compound 4 the middle estimate is 67 percentage points below the measured one; the whole stated range lies below it.
By their numbers in this assay, from the lowest: compounds 3 and 1 (each within the scatter of the next); then compound 2; then compound 4.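

Exchanging 4-(dimethylamino)phenyl for benzyl on a saturated chain carbon bound to an aromatic carbon and a carbonyl carbon gives, in this assay, a number 77 percentage points higher from compound 3 to compound 4 (beyond the scatter). Among these compounds, the earlier step concerned only the amide-type nitrogen, so this is the first sign that the chain carbon is also a position where one change can move the read-out far beyond the scatter. No measurement at hand explains this rise.

The entering benzyl differs from the leaving group in two ways at once, lacking the dimethylamino group and holding its ring through an extra carbon, and the compounds shown do not separate these two changes. Also open, on these data alone, is how a longer chain ending in the same ring, or a benzyl carrying a carboxylic acid, would behave at this position.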